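Amide in place of acid at the chain end

The source may hold more compounds than are shown below. What is called first, only, known or untested is meant among the compounds shown, and "the series" means these compounds.

Measured in a functional assay on CHO cells for agonist activity at Free fatty acid receptor 1 (Homo sapiens); on this read-out higher numbers stand for an effect only at larger amounts of compound and lower numbers for an effect already at smaller amounts:
compound 1 `Cc1nc(-c2ccc(C(F)(F)F)cc2)sc1CNc1ccc(CCC(=O)O)cc1` gives 67.6 nM
compound 2 `O=C(O)c1ccc(NCc2cccc(Oc3ccccc3)c2)cc1` gives < 10000 nM
compound 3 `Cc1nc(-c2ccc(C(F)(F)F)cc2)sc1CNc1ccc(CCCC(=O)O)cc1` gives < 10000 nM

Compound 2 stands at a limit of this assay, < 10000 nM, not at a number. The same holds for compound 3, whose value < 10000 nM is also a limit; thus the limit of < 10000 nM in this assay, at which 2 of the 3 values shown sit, covers two of the three values. Compound 4 `CNC(=O)CCc1ccc(NCc2cccc(Oc3ccccc3)c2)cc1` differs from compound 2 by 2-(methylcarbamoyl)ethyl in place of carboxy on an aromatic carbon. Among the compounds with values here, the only measured step touching the acid-bearing chain, a step that the limit leaves unreadable from compound 1 to compound 3, is unreadable, so no step bears on the size or direction of the change from compound 2 to compound 4. With compound 2 itself at a limit, compound 4 is expected to remain near that limit: a number no lower from compound 2 to compound 4 (the limit leaves the size open), estimated as 10000 nM within 3000 nM to 30000 nM.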

Compound 4, half-maximal effective concentration: 49 nM
Compound 4: the middle estimate sits 200-fold (2.31 log units) above what was measured, outside the stated range (below it).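

No step can be read between compound 2 and compound 4, because compound 2 carries a limit rather than a number: the limit of < 10000 nM in this assay, at which 2 of the 4 values shown sit.

The compounds shown leave open how large a change 2-(methylcarbamoyl)ethyl in place of carboxy brings.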